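The source may report more compounds than this note shows. Statements on the series, on what has been measured and on what is new or still open speak of the compounds shown alone.

Measured compounds in a physicochemical assay for solubility, at pH 7.4; a lower number here means a less soluble compound, a higher number a more soluble compound:
Compound 1 `C[C@H]1[C@H](N)CN1c1c(F)cc2c(=O)c(C(=O)O)cn(C3CC3)c2c1Cl` gives 12 ug/mL.
Compound 2 `CNC1(C)CN(c2c(F)cc3c(=O)c(C(=O)O)cn(C4CC4)c3c2F)C1` gives 0.5 ug/mL.
Compound 3 `CNC1CN(c2c(F)cc3c(=O)c(C(=O)O)cn(C4CC4)c3c2F)C1` gives 1.7 ug/mL.

Compound 3 stands second highest of the three numbers in this assay; compound 2 is nearest to it and compound 1 furthest. Among the measured compounds shown here, the single step between measured compounds, a 3.4-fold higher number from compound 2 to compound 3 (0.53 log units; beyond the scatter), concerns a saturated ring carbon and not the amine nitrogen, so no measured step bears directly on the change to compound 4 `CN(C)C1CN(c2c(F)cc3c(=O)c(C(=O)O)cn(C4CC4)c3c2F)C1`: methyl in place of hydrogen on an amine nitrogen. With no comparable change in the data, no step beyond the scatter is expected in this assay for compound 4. The expected step is a 1.1-fold lower number from compound 3 to compound 4 (0.05 log units; within the scatter). Compound 4 is estimated at 1.5 ug/mL, with a range from 0.5 ug/mL to 4.5 ug/mL.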

Compound 4, solubility: 58 ug/mL
Compound 4: the middle estimate sits 39-fold (1.59 log units) below what was measured; the whole stated range lies below it.
By their numbers in this assay, from the lowest: compound 2; then compound 3; then compound 1; then compound 4.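

In this assay the amine nitrogen proves a highly sensitive place: methyl in place of hydrogen there gives a 34-fold higher number from compound 3 to compound 4 (1.53 log units; beyond the scatter). The 3-(dimethylamino)azetidin-1-yl group also gives a 120-fold higher number from compound 2 to compound 4 (2.06 log units; beyond the scatter) in place of 3-methyl-3-(methylamino)azetidin-1-yl, so in these compounds methyl on the amine nitrogen and methyl on the saturated ring carbon go in opposite directions. Nothing at hand offers a reason for the size of this step.

Open, from the compounds shown here alone, is whether an ethyl group on that nitrogen, or the unsubstituted primary amine, follows the same trend. Also open, going by these compounds, is whether the change carries over to the core of compound 1.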